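The source may hold more compounds than are shown below. What is called first, only, known or untested is meant among the compounds shown, and "the series" means these compounds.

Measured so far in a functional assay on A549 cells (Homo sapiens) for antiproliferative activity, read by MTT assay, with a stated time of 48 h; a higher number here means a weaker inhibitor, a lower number a stronger inhibitor:
- compound 1 `CCN(CC)C/C1=C/C[C@](C)(CCC=C(C)C)/C=C/[C@@H](OC(=O)C=C(C)C)[C@](C)(O)/C=C/C1=O`: 130 nM
- compound 2 `CC[Si](CC)(CC)C/C1=C/C[C@](C)(CCC=C(C)C)/C=C/[C@@H](OC(=O)C=C(C)C)[C@](C)(O)/C=C/C1=O`: 3100 nM
- compound 3 `CC(C)=CCC[C@]1(C)/C=C/[C@@H](OC(=O)C=C(C)C)[C@](C)(O)/C=C/C(=O)/C(C[Si](C)(C)C(C)(C)C)=C\C1`: 4200 nM

Compound 3 sits at the weak end of this small set, level with compound 2: a 1.4-fold higher number from compound 2 to compound 3 (0.13 log units; within the scatter). Against compound 1 the gap is large: a 32-fold higher number from compound 1 to compound 3 (1.51 log units; beyond the scatter).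

The next compound is compound 4 `COCOC/C1=C/C[C@](C)(CCC=C(C)C)/C=C/[C@@H](OC(=O)C=C(C)C)[C@](C)(O)/C=C/C1=O`, which keeps the shared core and carries methoxymethoxy on a saturated chain carbon bound to a double-bonded ring carbon. The change is a group of 4 heavy atoms (2 carbon, 2 oxygen; no ring) in place of a group of 7 heavy atoms (6 carbon, 1 silicon; no ring), on a saturated chain carbon bound to a double-bonded ring carbon.

Within the data shown here, no measured compound carries this group, so no step speaks to it directly. The nearest evidence is the swap of the group on that same carbon in the other steps. Exchanging one silicon group for the other made no difference beyond the scatter, as a 1.4-fold higher number from compound 2 to compound 3 (0.13 log units; within the scatter) shows. Among the measured compounds shown here, both silicon compounds lie far from the one compound without silicon: a 24-fold higher number from compound 1 to compound 2 (1.38 log units; beyond the scatter) and a 32-fold higher number from compound 1 to compound 3 (1.51 log units; beyond the scatter). Compound 4 also has no silicon, but it lacks the nitrogen group of compound 1 as well, so only part of that distance is expected to be recovered.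

The expected move in this assay is towards a lower number, moderate in size, and the uncertainty is wide: a 4.2-fold lower number from compound 3 to compound 4 (0.62 log units; beyond the scatter) is the estimated step. For compound 4 the estimate is 1000 nM, with an expected range from 250 nM to 4000 nM.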

Compound 4, half-maximal inhibitory concentration: 2980 nM
For compound 4 the middle estimate is 3.0-fold (0.47 log units) below the measured one; the measured number falls inside the stated range.
By their numbers in this assay, from the lowest: compound 1; then compounds 4, 2 and 3 (each within the scatter of the next).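

In this assay, methoxymethoxy on the saturated chain carbon bound to a double-bonded ring carbon sits level with both silicon groups (a 1.4-fold lower number from compound 3 to compound 4 (0.15 log units; within the scatter); a 1.0-fold lower number from compound 2 to compound 4 (0.02 log units; within the scatter)), so a group without silicon does not by itself close the distance to compound 1. That distance stays large (a 23-fold higher number from compound 1 to compound 4 (1.36 log units; beyond the scatter)): among these four compounds, only compound 1, with diethylamino, stands apart, while the three groups without nitrogen remain within the scatter of one another, even though methoxymethoxy has hydrogen-bond acceptors and the silicon group it replaces has none. No accompanying measurement bears on why the diethylamino compound stands apart.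

Still open, on these data alone, is whether the nitrogen itself or the ethyl groups around it carry the difference, which a dimethylamino group, a primary amine or a morpholine ring on the same carbon would help separate. Also open, as far as these compounds go, is how a free hydroxyl or a carboxylic acid there would compare with methoxymethoxy and with diethylamino.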